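Replacing the Phenyl of Compound 2 with Fluoro

This account rests on a few compounds, and the source may have more. Where it says the series, first, only, none or still open, it means among the compounds named here.

In a toxicity assay on WI-38 cells (Homo sapiens) for inhibition, read by MTT assay, with a stated time of 72 h (a lower number here means a stronger inhibitor, a higher number a weaker inhibitor), compound 1 `Cc1ccc(N2CCCC2)c(C(=O)Nc2ccc(CNC(=O)OCc3cccnc3)cc2)c1` gives 40600 nM. Compound 2 `O=C(NCc1ccc(NC(=O)c2cc(-c3ccccc3)ccc2N2CCCC2)cc1)OCc1cccnc1` carries a phenyl where compound 1 carries a methyl. The result for compound 2 is a limit of the assay, > 100000 nM, and not a number. Compound 3 `O=C(NCc1ccc(NC(=O)c2cc(F)ccc2N2CCCC2)cc1)OCc1cccnc1` changes that same group again: fluoro in place of phenyl on an aromatic carbon, meta to a large group and para to a pyrrolidin-1-yl group.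

For the measured compounds named here, only one measured step bears on this change, namely an at least 2.4-fold higher number from compound 1 to compound 2 (0.39 log units; beyond the scatter), for phenyl in place of methyl on an aromatic carbon. Losing the phenyl runs the opposite way in kind, though fluoro is not methyl, and the size of the measured step is known only as a bound. A lower number in this assay is therefore expected, of a size similar to that step, and the expected change is an at least 2.0-fold lower number from compound 2 to compound 3 (0.30 log units; that floor lies within the scatter). For compound 3 the estimated value is 50000 nM, with an expected range of 20000 nM to 100000 nM.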

Compound 3, half-maximal inhibitory concentration: > 100000 nM
Compound 3: no number, only a limit (the forecaster's own chance of this, stated with the estimate: 30%); middle value at least 2.0-fold (0.30 log units) from the limit.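

In this assay, the result shows that the rise seen with phenyl at this position, meta to a large group and para to a pyrrolidin-1-yl group, does not need a group of that size. Fluoro, with 1 heavy atom against the 6 heavy atoms of phenyl, gives an at least 2.4-fold higher number from compound 1 to compound 3 (0.39 log units; beyond the scatter), so among the three compounds only compound 1, with its methyl, gives a number inside the range of the assay. The step from compound 2 to compound 3 cannot be read, because both compounds stand at a limit and not at a number: the limit of > 100000 nM in this assay, at which 2 of the 3 values shown sit.

On these data alone, how far compound 2 and compound 3 lie past that limit stays open, and so does whether phenyl and fluoro differ at all at this position. The compounds shown also leave open whether a chloro, a methoxy or an amino group at this place would give a number near that of compound 1 or would likewise end at the limit.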